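The source may report more compounds than this note shows. Statements on the series, on what has been measured and on what is new or still open speak of the compounds shown alone.

Compound 1 `COc1ccc(-n2cc(CN3C(=O)C[C@@H]4CC[C@@]3(C)C4(C)C)nn2)cc1`: 250 nM
Compound 2 `CC1(C)[C@H]2CC[C@]1(C)N(Cc1cn(-c3ccccc3)nn1)C(=O)C2`: 50 nM
Compound 3 `CC1(C)[C@H]2CC[C@]1(C)N(Cc1cn(-c3cccc(Br)c3)nn1)C(=O)C2`: 30 nM

Of the compounds shown here, three sharing one core have been measured in a functional assay on OVCAR-3 cells (Homo sapiens) for inhibition, read by MTT assay, with a stated time of 24 h; a lower number here means a stronger inhibitor, a higher number a weaker inhibitor. Compound 1 gives the highest of the three numbers, with the other two both well separated from it: a 5.0-fold lower number from compound 1 to compound 2 (0.70 log units; beyond the scatter), and an 8.3-fold lower number from compound 1 to compound 3 (0.92 log units; beyond the scatter). Between compound 2 and compound 3 the gap is smaller, a 1.7-fold lower number from compound 2 to compound 3 (0.22 log units; within the scatter), so these two cannot be ordered on the numbers alone.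

Compound 4 `CC1(C)[C@H]2CC[C@]1(C)N(Cc1cn(-c3cccc(C#N)c3)nn1)C(=O)C2` is not yet measured. It differs from compound 1 at the group on the aromatic nitrogen: 3-cyanophenyl in place of 4-methoxyphenyl on an aromatic nitrogen

Within the data shown here, two measured steps bear on this change. Both replacements of the 4-methoxyphenyl group of compound 1, whether by phenyl or by 3-bromophenyl, gave clearly lower numbers, and the further step from phenyl to 3-bromophenyl stayed within the scatter. Compound 4 carries a 3-cyanophenyl group, a substituted phenyl ring like that of compound 3, so the step is expected to resemble the step from compound 1 to compound 3, and a lower number beyond the scatter is expected for compound 4 in this assay, of roughly a 5.6-fold lower number from compound 1 to compound 4 (0.74 log units; beyond the scatter). On that basis compound 4 is estimated at 45 nM, with a plausible range from 15 nM to 130 nM.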

Compound 4, half-maximal inhibitory concentration: 230 nM
The estimate for compound 4 lay 5.1-fold (0.71 log units) below the measured number; the whole stated range lies below it.
By their numbers in this assay, from the lowest: compounds 3 and 2 (each within the scatter of the next); then compounds 4 and 1 (each within the scatter of the next).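

In this assay, the lower numbers seen when phenyl or 3-bromophenyl replaced 4-methoxyphenyl do not extend to every substituted phenyl ring on the aromatic nitrogen: 3-cyanophenyl gives only a 1.1-fold lower number from compound 1 to compound 4 (0.04 log units; within the scatter) and so cannot be told apart from 4-methoxyphenyl. Among these compounds, the identity of the substituent on this ring therefore matters in a way the earlier compounds could not show, since cyano in place of bromo gives a 7.7-fold higher number from compound 3 to compound 4 (0.88 log units; beyond the scatter) and cyano in place of hydrogen gives a 4.6-fold higher number from compound 2 to compound 4 (0.66 log units; beyond the scatter) on the same aromatic carbon. Cyano thus goes against the picture of a substituted phenyl ring behaving like 3-bromophenyl, and nothing available here accounts for the difference between these groups.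

The compounds shown leave open where 3-chlorophenyl, 3-methylphenyl or 3-aminophenyl would fall on this position, and so whether bromo and hydrogen or cyano is the exception. They also leave open whether 4-bromophenyl or 4-cyanophenyl would follow their 3-substituted counterparts, and how 3-methoxyphenyl would compare with 4-methoxyphenyl.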